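The source may report more compounds than this note shows. Statements on the series, on what has been measured and on what is new or still open speak of the compounds shown alone.

Measured so far:
- compound 1, `CCCOC(=O)/C=C(C)/C=C/CC(C)CCCC(C)C`: 7.28
- compound 2, `CC(/C=C/CC(C)CCCC(C)C)=C\C(=O)OC(C)C`: 7.15
- compound 3, `CC#CCOC(=O)/C=C(C)/C=C/CC(C)CCCC(C)C`: 6.4

These three compounds were examined in a physicochemical assay for lipophilicity; on this read-out lower numbers stand for lower lipophilicity and higher numbers for higher lipophilicity. Compound 2 stands second highest of the three numbers; its nearest neighbour is compound 1, with a difference of a number 0.13 log units lower from compound 1 to compound 2 (within the scatter), and its furthest is compound 3, with a number 0.75 log units lower from compound 2 to compound 3 (beyond the scatter). The remaining measured step, a number 0.88 log units lower from compound 1 to compound 3 (beyond the scatter), is of similar size.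

Compound 4, `COC(C)(C)C(O)CCC(C)C/C=C/C(C)=C/C(=O)OC(C)C`, has not yet been measured in this assay. It differs from compound 2 by 1-hydroxy-2-methoxy-2-methylpropyl in place of isobutyl on a saturated chain carbon, four bonds along the chain from a double-bonded chain carbon. Within the data shown here, none of the measured steps touches this part of the molecule: all three concern the group on the oxygen next to the carbonyl group, and the largest of them was only modest. The change to compound 4 is of a different kind, bringing in a hydroxyl and a methoxy where compound 2 carries only carbon. The expected direction is therefore downward in this assay, and the step is expected to be larger than any measured here, though its exact size is uncertain. The estimated step is a number 1.85 log units lower from compound 2 to compound 4 (beyond the scatter). Compound 4 is expected to give about 5.3, with a range from 4.5 to 6.1.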

Compound 4, partition coefficient: 3.86
Compound 4: middle estimate off by 1.44 log units, on the high side; the measured number lies below the stated range.
By their numbers in this assay, from the lowest: compound 4; then compound 3; then compounds 2 and 1 (each within the scatter of the next).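

In this assay, among these compounds, the saturated chain carbon four bonds along the chain from a double-bonded chain carbon proves far more sensitive than anything the earlier compounds showed: putting 1-hydroxy-2-methoxy-2-methylpropyl in place of isobutyl gives a number 3.29 log units lower from compound 2 to compound 4 (beyond the scatter), a large step that dwarfs the modest changes seen on the oxygen next to the carbonyl group. The entering group has 1 hydrogen-bond donor and 2 hydrogen-bond acceptors, where isobutyl has none, so a swap with no ring and no net charge on either side can still move this read-out a long way. Nothing in the data explains the size of this step.

As far as these compounds go, the hydroxyl and the methoxy arrive together in one group, so how much of the step belongs to each remains open. Also open, from the compounds shown here alone, are how an amine, a carboxylic acid or a longer plain carbon chain would read at this place, and whether the step would keep its size with propyl or but-2-yn-1-yl on the oxygen next to the carbonyl group.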